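Amide side-chain change from compound 1 to compound 4

The compounds below may be only part of what the source reports. "The series", "measured", "known", "first", "only" and "open" are said of these compounds alone.

Measured so far:
compound 1 `N[C@H]1CC[C@H](Nc2c(C(=O)NCc3ccco3)nc(Br)c3cccnc23)CC1`: in a functional assay on MDA-MB-435 cells (Homo sapiens) for cytotoxicity, read by MTT assay, with a stated time of 72 h (on this read-out higher numbers stand for weaker inhibition and lower numbers for stronger inhibition), compound 1 gives > 10000 nM, a limit of the assay.
compound 2 `NCCCNc1c(C(=O)NCc2ccc(F)cc2)ncc2cccnc12`: in this assay compound 2 gives 16000 nM.
compound 3 `O=C(NCc1ccc(F)cc1)c1nc(NCCO)c2cccnc2c1O`: in this assay compound 3 gives > 20000 nM, a limit of the assay.

Compound 1 stands only at a limit, (the limit of > 10000 nM in this assay, at which 1 of the 3 values shown sits), so no number places it against the others. For the measured compounds named here, compound 2 carries the one numbered value in the set. Compound 3 sits at a limit, (the limit of > 20000 nM in this assay, at which 1 of the 3 values shown sits). Compound 4 `N[C@H]1CC[C@H](Nc2c(C(=O)NCc3ccc(Cl)cc3Cl)nc(Br)c3cccnc23)CC1` differs from compound 1 by 2,4-dichlorophenyl in place of furan-2-yl on a saturated chain carbon bound to an amide-type nitrogen. Going by the values given here, no step between two measured compounds is available, so the size of this change has no precedent here. The expected step from compound 1 to compound 4 is an at least 1.2-fold lower number from compound 1 to compound 4 (0.09 log units; that floor lies within the scatter), a small gain in inhibition at most. Compound 4 is expected at 8000 nM, within 2000 nM to 30000 nM, with a real chance that only a limit is reported again.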

Compound 4, half-maximal inhibitory concentration: 5800 nM
Compound 4: the middle estimate sits 1.4-fold (0.14 log units) above what was measured, and the stated range covers the measured number.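

In this assay, 2,4-dichlorophenyl in place of furan-2-yl on a saturated chain carbon bound to an amide-type nitrogen gives an at least 1.7-fold lower number from compound 1 to compound 4 (0.23 log units; that floor lies within the scatter). For the compounds shown here, this is the first step readable at this place, and it gives a number on the shared core of compound 1, which itself holds only a limit: the limit of > 10000 nM in this assay, at which 1 of the 4 values shown sits. The true size of the step is therefore unknown and may exceed its floor.

As far as these compounds go, whether the chlorine atoms or the six-membered ring carries the step stays open. From the compounds shown here alone, how a plain benzyl or a longer 2-phenylethyl chain would read on this core also stays open.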